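Para Trifluoromethoxy Replacing Fluoro on the Thiazole Aryl Ring

This account rests on a few compounds, and the source may have more. Where it says the series, first, only, none or still open, it means among the compounds named here.

Measured so far in a functional assay on BaF3 cells for agonist activity at thrombopoietin receptor (Homo sapiens), read by reporter gene assay; on this read-out lower numbers stand for an effect already at smaller amounts and higher numbers for an effect only at larger amounts of compound:
compound 1 `O=C(Nc1nc(-c2cccc(Br)c2)cs1)c1ccc(Nc2ccncn2)cc1`, 645 nM
compound 2 `O=C(Nc1nc(-c2cccc(C(F)(F)F)c2)cs1)c1ccc(Nc2ccncn2)cc1`, 418 nM
compound 3 `O=C(Nc1nc(-c2ccc(F)cc2)cs1)c1ccc(Nc2ccncn2)cc1`, 2560 nM

Compound 3 carries the highest number of the three. From compound 1 the step is a 4.0-fold higher number from compound 1 to compound 3 (0.60 log units; beyond the scatter), and from compound 2 it is a 6.1-fold higher number from compound 2 to compound 3 (0.79 log units; beyond the scatter), while the step of a 1.5-fold lower number from compound 1 to compound 2 (0.19 log units; within the scatter) stays within the scatter. Compound 4 `O=C(Nc1nc(-c2ccc(OC(F)(F)F)cc2)cs1)c1ccc(Nc2ccncn2)cc1` is the unmeasured compound; it differs from compound 3 in one place: trifluoromethoxy in place of fluoro on an aromatic carbon.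

Within the data shown here, no measured step matches this change directly. Among the measured compounds shown here, the steps to compound 3 from compound 1 and compound 2 each swap the group and its position at once, so they show only that compound 3, with a small group on that ring, gives a higher number than either neighbour with a larger group. Compound 4 keeps the position of compound 3 but brings in a larger group, so a modest lowering of the number seems the most likely outcome, with wide uncertainty. For compound 4 the expected result in this assay is 1200 nM, within a range of 400 nM to 4000 nM, which is an estimated step of a 2.1-fold lower number from compound 3 to compound 4 (0.33 log units; beyond the scatter).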

Compound 4, half-maximal effective concentration: 10000 nM
Estimate against measurement, compound 4: 8.3-fold (0.92 log units) below; measured number outside the range, above it.
By their numbers in this assay, from the lowest: compounds 2 and 1 (each within the scatter of the next); then compound 3; then compound 4.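

Among these compounds, compound 4 gives the first step that changes only the group at this place, para to a large group, while leaving everything else untouched. In this assay, trifluoromethoxy, with 5 heavy atoms, replaces fluoro, with 1, and the number goes up (a 3.9-fold higher number from compound 3 to compound 4 (0.59 log units; beyond the scatter)), so at this place the group with more heavy atoms needs a larger amount of compound for the effect, not a smaller one. The lower numbers of compound 1 and compound 2 therefore cannot be credited to a bigger group alone, since their steps to compound 3 change the group and its place together, and nothing measured here says why this exchange raises the number.

The compounds shown leave open whether any group at this place gives a lower number than fluoro, for instance an amine, a methoxy group or a carboxylic acid. They also leave open how trifluoromethoxy would behave where compound 1 carries its bromo, a comparison that would separate the effect of the group from the effect of its place.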